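Exchanging the benzyl group of a weakly active amide

The source may hold more compounds than are shown below. What is called first, only, known or untested is meant among the compounds shown, and "the series" means these compounds.

Compound 1 `O=C(NCc1cn(Cc2ccc(F)cc2)nn1)c1cn(-c2ccccc2)nc1-c1ccccc1` and compound 2 `O=C(NCc1cn(Cc2ccc(F)cc2)nn1)c1cn(-c2ccccc2)nc1-c1ccc(F)cc1` share one core and are set apart only by fluoro in place of hydrogen on an aromatic carbon. In a functional assay on MCF7 cells (Homo sapiens) for antiproliferative activity, read by sulforhodamine B assay, with a stated time of 48 h (a lower number here means a stronger inhibitor of growth, a higher number a weaker inhibitor of growth), compound 1 gives 7000 nM, and compound 2 gives 55300 nM, the higher of the two numbers; the step of a 7.9-fold higher number from compound 1 to compound 2 (0.90 log units; beyond the scatter) lies beyond the scatter. Compound 3 `COc1cc(Cn2cc(CNC(=O)c3cn(-c4ccccc4)nc3-c3ccc(F)cc3)nn2)cc(OC)c1` is reached from compound 2 by a different change, (3,5-dimethoxyphenyl in place of 4-fluorophenyl on a saturated chain carbon bound to an aromatic nitrogen). Among the measured compounds shown here, the only measured step concerned a fluoro on an aromatic carbon elsewhere in the molecule and says nothing about the 4-fluorobenzyl group that is replaced here, so no measured step bears directly on this change. The estimate for compound 3 in this assay is therefore placed near its parent, at 40000 nM, with a range from 10000 nM to 150000 nM. The expected step of a 1.4-fold lower number from compound 2 to compound 3 (0.14 log units; within the scatter) is thus not beyond the scatter.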

Compound 3, concentration for 50% growth inhibition: 2500 nM
Compound 3: middle estimate off by 16-fold (1.20 log units), on the high side; measured number below the stated range.
By their numbers in this assay, from the lowest: compound 3; then compound 1; then compound 2.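

In this assay, exchanging 4-fluorobenzyl for 3,5-dimethoxybenzyl gives a 22-fold lower number from compound 2 to compound 3 (1.34 log units; beyond the scatter), a large step toward stronger growth inhibition. Among the compounds shown here, the earlier pair had varied only a fluoro on an aromatic carbon elsewhere in the molecule, so this is the first sign that the group on the saturated chain carbon bound to an aromatic nitrogen also governs activity, and that changing it can improve the number. No supporting measurement is available to explain why this exchange has such an effect.

The compounds shown leave open whether a benzyl group with a single methoxy, or an unsubstituted benzyl group, would give a similar result. They also leave open whether ethoxy groups in place of the methoxy groups would hold the gain, and whether 3,5-dimethoxybenzyl would act the same way on the core of compound 1.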